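The source may report more compounds than this note shows. Statements on the series, on what has been measured and on what is new or still open speak of the compounds shown alone.

Measured in a functional assay on ES2 cells (Homo sapiens) for inhibition, read by MTT assay, with a stated time of 48 h; a lower number here means a stronger inhibitor, a higher number a weaker inhibitor:
- compound 1 `O=C(CCCOC(=O)c1ccc2c(c1)no[n+]2[O-])NO`: 27100 nM
- compound 2 `O=C(CCCCOC(=O)c1ccc2c(c1)no[n+]2[O-])NO`: 25000 nM
- compound 3 `O=C(CCCCCCOC(=O)c1ccc2c(c1)no[n+]2[O-])NO`: 5070 nM

Of these three, compound 3 gives the lowest number, 5070 nM, and it stands apart from both others beyond the scatter. The next analogue, compound 4 `O=C(CCCCCCCOC(=O)c1ccc2c(c1)no[n+]2[O-])NO`, differs from it by (hydroxycarbamoyl)methyl in place of hydroxycarbamoyl on a saturated chain carbon, six bonds along the chain from an oxygen next to a carbonyl group, with (hydroxycarbamoyl)methyl in place of hydroxycarbamoyl on a saturated chain carbon, six bonds along the chain from an oxygen next to a carbonyl group.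

The same replacement, made at a different place on the chain, gave a 1.1-fold lower number from compound 1 to compound 2 (0.04 log units; within the scatter). The larger replacement, 2-(hydroxycarbamoyl)ethyl in place of hydroxycarbamoyl, gave a 4.9-fold lower number from compound 2 to compound 3 (0.69 log units; beyond the scatter). The two measured steps therefore disagree in size, and the first goes against any steady fall with chain extension. Only a small further lowering is expected in this assay, probably not beyond the scatter. The expected change is a 1.3-fold lower number from compound 3 to compound 4 (0.10 log units; within the scatter). For compound 4 the estimate is 4000 nM, with an expected range from 1500 nM to 10500 nM.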

Compound 4, half-maximal inhibitory concentration: 9230 nM
Estimate against measurement, compound 4: 2.3-fold (0.36 log units) below, and the stated range covers the measured number.
By their numbers in this assay, from the lowest: compounds 3 and 4 (each within the scatter of the next); then compounds 2 and 1 (each within the scatter of the next).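

In this assay, (hydroxycarbamoyl)methyl in place of hydroxycarbamoyl, on a saturated chain carbon six bonds along the chain from an oxygen next to a carbonyl group, gave a 1.8-fold higher number from compound 3 to compound 4 (0.26 log units; within the scatter), so this further lengthening brings no measurable gain. Compound 4 nevertheless stays clear of the two shorter chains, with a 2.7-fold lower number from compound 2 to compound 4 (0.43 log units; beyond the scatter) and a 2.9-fold lower number from compound 1 to compound 4 (0.47 log units; beyond the scatter). The same small change thus does little at either chain length, a reading that now rests on two pairs: the same change on two cores in this assay, a 1.1-fold lower number (0.04 log units; within the scatter) from compound 1 to compound 2 and a 1.8-fold higher number (0.26 log units; within the scatter) from compound 3 to compound 4, 2.0-fold (0.30 log units) apart, within the scatter of two such steps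

Going by these compounds, whether a longer chain than that of compound 4 would hold this level or lose it stays open, as does where the lower numbers set in on going from compound 2 to compound 3. Also open, on these data alone, is what a carboxylic acid in place of hydroxycarbamoyl would do on these chains.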